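Bromo to ethoxymethyl: the next step in the series

A few compounds are considered here, and "the series" means these few. Any claim that something is new, unique, unknown or untested is made for them only; others in the source may bear on it.

Compound 1 (`Oc1c(CN2CCCC2)cc(Cl)c2cccnc12`): 300 nM; 295 nM (2 entries)
Compound 2 (`Oc1c(CN2CCCC2)cc(Br)c2cccnc12`): 389 nM

Both compounds were read in a functional assay on MES-SA/Dx5 cells (Homo sapiens) for inhibition, with a stated time of 72 h (on this read-out lower numbers stand for stronger inhibition and higher numbers for weaker inhibition), and the repeat entries of compound 1 agree closely (the several entries of compound 1 in this assay, 300 nM; 295 nM (2 entries)). Among the compounds with values here, compound 2 has 389 nM as its only number, and one further entry gives no single number. That number lies within the usual scatter of compound 1 (300 nM; 295 nM (2 entries)) so the two cannot be ranked.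

Compound 3 (`CCOCc1cc(CN2CCCC2)c(O)c2ncccc12`) is still unmeasured. It carries ethoxymethyl in place of bromo on an aromatic carbon. Within the data shown here, no measured step covers this kind of change, so only a moderate weakening is expected, estimated as a 1.8-fold higher number from compound 2 to compound 3 (0.26 log units; within the scatter) in this assay with wide uncertainty. Compound 3 is expected at 700 nM with an estimated range of 250 nM to 2200 nM in this assay for now.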

Compound 3, half-maximal inhibitory concentration: 912 nM
Beside the measured number, compound 3's estimate is 1.3-fold (0.11 log units) below it; low and high end bracket the measured number.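

At the position para to a hydroxy group, the series now has its first step beyond the scatter in this assay: a 2.3-fold higher number from compound 2 to compound 3 (0.37 log units; beyond the scatter), with ethoxymethyl in place of bromo. Compound 1 and compound 2 could not be ranked, so the change from chloro to bromo resolved nothing here, whereas a group of 4 heavy atoms with 1 hydrogen-bond acceptor gives a modest shift towards weaker inhibition and leaves a measurable value. Nothing measured in this set speaks to the origin of this step.

The compounds shown leave open whether the ether oxygen or the chain length carries the step. Also open, from the compounds shown here alone, is how a butyl chain, a primary amine or a carboxylic acid would read at this position, and whether the step holds with another group in place of (pyrrolidin-1-yl)methyl.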